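Swapping the amide aryl group on a second core

This account rests on a few compounds, and the source may have more. Where it says the series, first, only, none or still open, it means among the compounds named here.

Compound 1 `O=C(c1ccc(Cl)c(C(F)(F)F)c1)N1CCC(n2cncc2-c2ccc(OS(=O)(=O)c3cccc4cnccc34)cc2)CC1` and compound 2 `CS(=O)(=O)c1ccc(C(=O)N2CCC(n3cncc3-c3ccc(OS(=O)(=O)c4cccc5cnccc45)cc3)CC2)cc1` share one core and differ only in the group on the amide carbonyl. In an assay on THP-1 cells for antagonist activity at P2X purinoceptor 7 (Homo sapiens), read by ELISA, with a stated time of 30 min (a lower number here means a stronger inhibitor, a higher number a weaker inhibitor), compound 1 gives 22 nM, and compound 2 gives 0.32 nM. That change, (4-(methylsulfonyl)phenyl in place of 4-chloro-3-(trifluoromethyl)phenyl on a carbonyl carbon), produced a 69-fold lower number from compound 1 to compound 2 (1.84 log units; beyond the scatter).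

Compound 3 `O=C(c1ccc(Cl)c(C(F)(F)F)c1)N1CCC(c2nc3cc(OS(=O)(=O)c4cccc5cnccc45)ccc3[nH]2)CC1` carries the same aryl amide as compound 1 on a different core; the difference between the two cores is not broken down here. In this assay compound 3 gives 210 nM, the highest of the three numbers.

Compound 4 `CS(=O)(=O)c1ccc(C(=O)N2CCC(c3nc4cc(OS(=O)(=O)c5cccc6cnccc56)ccc4[nH]3)CC2)cc1` applies the same kind of change to the core of compound 3: 4-(methylsulfonyl)phenyl in place of 4-chloro-3-(trifluoromethyl)phenyl on a carbonyl carbon. The place is described in the same words for both pairs, so the only new factor is the core. For the measured compounds named here, the step is expected to be large again, as a 53-fold lower number from compound 3 to compound 4 (1.72 log units; beyond the scatter), because the one measured instance gave a 69-fold lower number from compound 1 to compound 2 (1.84 log units; beyond the scatter). Going by the values given here, with only a single precedent on another core, a somewhat smaller or larger step would not be surprising. Compound 4 is therefore expected to give about 4 nM, between 1 nM and 25 nM.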

Compound 4, half-maximal inhibitory concentration: 43 nM
Beside the measured number, compound 4's estimate is 11-fold (1.03 log units) below it; the measured number lies above the stated range.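

In this assay, putting 4-(methylsulfonyl)phenyl in place of 4-chloro-3-(trifluoromethyl)phenyl on the carbonyl carbon again gives a stronger inhibitor on the second core, with a 4.9-fold lower number from compound 3 to compound 4 (0.69 log units; beyond the scatter). The direction of the change carries over from one core to the other, but its size does not, and the gap between the two steps is larger than repeat measurements would produce: the same change on two cores in this assay, a 69-fold lower number (1.84 log units; beyond the scatter) from compound 1 to compound 2 and a 4.9-fold lower number (0.69 log units; beyond the scatter) from compound 3 to compound 4, 14-fold (1.15 log units) apart, beyond the scatter of two such steps. So the core matters to how much this swap gains, but these two pairs do not show which feature of the core is responsible, and they give no rule for predicting the size of the step on a third core.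

The compounds shown leave open whether the gain is specific to the methylsulfonyl group or would also appear with another group on that phenyl ring, such as a carboxylic acid or an amine. They also leave open how a simple unsubstituted phenyl would behave on either core.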